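The source may hold more compounds than are shown below. What is called first, only, known or untested is meant among the compounds shown, and "the series" means these compounds.

Measured in a functional assay on Huh-7 cells (Homo sapiens) for antiproliferative activity, read by sulforhodamine B assay, with a stated time of 72 h; on this read-out lower numbers stand for stronger inhibition and higher numbers for weaker inhibition: compound 1 `Cc1ccccc1COc1ccc(-c2cc(CN3CCN(Cc4ccc(C(F)(F)F)cc4)CC3)no2)cc1` gives 1200 nM; compound 2 `Cc1cccc(COc2ccc(-c3cc(CN4CCN(Cc5ccc(C(F)(F)F)cc5)CC4)no3)cc2)c1` gives 5000 nM; compound 3 `FC(F)(F)c1ccc(CN2CCN(Cc3cc(-c4ccc(OCc5cccc(Cl)c5)cc4)on3)CC2)cc1` gives 200 nM.

Compound 3 stands lowest of the three, with a 6.0-fold lower number from compound 1 to compound 3 (0.78 log units; beyond the scatter) and a 25-fold lower number from compound 2 to compound 3 (1.40 log units; beyond the scatter). The step to compound 4 `FC(F)(F)c1ccc(CN2CCN(Cc3cc(-c4ccc(OCc5ccc(Cl)cc5)cc4)on3)CC2)cc1` is 4-chlorophenyl in place of 3-chlorophenyl on a saturated chain carbon bound to an oxygen on an aromatic ring. For the measured compounds named here, no measured step moves a chloro on this ring. Going by the values given here, the only positional comparison available is a 4.2-fold higher number from compound 1 to compound 2 (0.62 log units; beyond the scatter), a methyl case, which was modest and beyond the scatter, and the methyl-to-chloro swap a 25-fold lower number from compound 2 to compound 3 (1.40 log units; beyond the scatter) was large. So a modest step in this assay is expected, direction not fixed by the data. The expected step is a 2.0-fold higher number from compound 3 to compound 4 (0.30 log units; within the scatter). Compound 4 is expected at 400 nM, range 100 nM to 1600 nM.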

Compound 4, half-maximal inhibitory concentration: 4000 nM
Compound 4: the middle estimate sits 10-fold (1.00 log units) below what was measured; the measured number lies above the stated range.
By their numbers in this assay, from the lowest: compound 3; then compound 1; then compounds 4 and 2 (each within the scatter of the next).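

In this assay, moving the chloro alone matters greatly on this ring: 4-chlorophenyl in place of 3-chlorophenyl gives a 20-fold higher number from compound 3 to compound 4 (1.30 log units; beyond the scatter), so the low number of compound 3 belongs to 3-chlorophenyl and not to chloro at any position. Against the methyl compounds, the 4-chlorophenyl change reads a 1.3-fold lower number from compound 2 to compound 4 (0.10 log units; within the scatter) and a 3.3-fold higher number from compound 1 to compound 4 (0.52 log units; beyond the scatter). Nothing at hand bears on why the position matters.

Open, going by these compounds, is whether the same positional gap appears with a bromo or a methoxy in place of the chloro. Also open, on these data alone, is how an unsubstituted phenyl compares at this saturated chain carbon.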